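This account rests on a few compounds, and the source may have more. Where it says the series, first, only, none or still open, it means among the compounds named here.

Compound 1 `CC(O)(C(=O)Nc1ccc(S(=O)(=O)c2ccccc2)c(C(=O)O)c1)C(F)(F)F` gives > 30000 nM in a functional assay (Cavia porcellus) with sulfonylurea receptors; K-ATP channels (Homo sapiens) as the target (on this read-out higher numbers stand for weaker inhibition and lower numbers for stronger inhibition), which is a limit of the assay. Compound 2 `CC(O)(C(=O)Nc1ccc(C(=O)c2ccccc2)cc1F)C(F)(F)F` gives 11000 nM in this assay. Compound 3 `CC(O)(C(=O)Nc1ccc(C(=O)c2ccccc2F)cc1)C(F)(F)F` gives 2300 nM in this assay.

Of the two numbers shown, compound 2 has the highest; the nearest is compound 3, whose lower number lies beyond the usual scatter. For compound 1 only a limit is known (the limit of > 30000 nM in this assay, at which 1 of the 3 values shown sits), so it gives no number to set against.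

Compound 4 `CC(O)(C(=O)Nc1ccc(C(=O)c2ccccc2)cc1Cl)C(F)(F)F` differs from compound 2 by chloro in place of fluoro on an aromatic carbon. No measured step of this kind is available among these compounds. In this assay a small step is expected, a 1.4-fold lower number from compound 2 to compound 4 (0.14 log units; within the scatter), within the scatter or a little toward stronger inhibition. Compound 4 is therefore estimated at 8000 nM, between 2500 nM and 30000 nM.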

Compound 4, half-maximal inhibitory concentration: > 30000 nM
Compound 4: a limit, no number; the forecaster's own chance of this, stated with the estimate: 15%; middle value at least 3.7-fold (0.57 log units) from the limit.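

Until now no step in one place could be read among these compounds; this is the first, and it shows that this position, ortho to a large group and meta to a benzoyl group, does not tolerate every halogen alike in this assay. Chloro in place of fluoro gives an at least 2.7-fold higher number from compound 2 to compound 4 (0.43 log units; beyond the scatter), a move toward weaker inhibition. Compound 4 has only a limit, so this step gives a minimum and its full size stays unknown: the limit of > 30000 nM in this assay, at which 2 of the 4 values shown sit.

As far as these compounds go, whether a methyl or methoxy group here would behave more like fluoro or chloro stays open. So does whether chloro in place of the fluoro of compound 3 would move the read-out the same way.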